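Methyl to amino: one change, one unmeasured compound

The source may report more compounds than this note shows. Statements on the series, on what has been measured and on what is new or still open speak of the compounds shown alone.

Measured so far in a functional assay on the whole organism with Mus musculus as the target, in the maximal electroshock model, with a stated time of 30 min; a lower number here means that less compound is needed, a higher number that more compound is needed for the effect:
Compound 1 `O=C(Nc1ccncc1)Nc1ccccc1F` gives 100 mg/kg.
Compound 2 `O=C(Nc1ccncc1)Nc1ccc([N+](=O)[O-])cc1` reaches only a limit of the assay, > 300 mg/kg.
Compound 3 `Cc1ccc(NC(=O)Nc2ccncc2)cc1` likewise reaches only a limit, > 300 mg/kg.

Where compound 3 stands is therefore not a number but a limit, and it shares that limit with compound 2 (the limit of > 300 mg/kg in this assay, at which 2 of the 3 values shown sit). The step that the two limits leave unreadable from compound 2 to compound 3 cannot be read in size: both of its ends are limits. Going by the values given here, only compound 1 gives a number, and no step between it and the others is computed, so its value shows merely that one member of this set does reach an effect in this assay.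

Compound 4 `Nc1ccc(NC(=O)Nc2ccncc2)cc1` differs from compound 3 in one place: amino in place of methyl on an aromatic carbon. Among the compounds with values here, no measured step bears directly on this change, and the one measured step, from compound 2 to compound 3, is unreadable. With nothing to set a direction, the expectation for compound 4 is no step beyond the scatter, and the most likely outcome is that the assay again reports only a limit. Compound 4 is therefore estimated at 300 mg/kg, within 150 mg/kg to 600 mg/kg. This estimate means an expected step of a number no higher from compound 3 to compound 4 (the limit leaves the size open).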

Compound 4, minimum effective dose: > 300 mg/kg
Compound 4: no number, only a limit; the forecaster's own chance of this, stated with the estimate: 60%; the middle value lies on the limit itself.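

In this assay compound 4 again gives only a limit, > 300 mg/kg. The steps linking compound 2, compound 3 and compound 4 therefore cannot be read in size, since each of the three compounds stands at the same limit: the limit of > 300 mg/kg in this assay, at which 3 of the 4 values shown sit.

The compounds shown leave open how far amino, methyl and nitro differ from one another in minimum effective dose.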